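This account rests on a few compounds, and the source may have more. Where it says the series, first, only, none or still open, it means among the compounds named here.

Measured so far:
compound 1, `Fc1ccc(/C=N/Nc2nc(-c3cc(C(F)(F)F)cc(C(F)(F)F)c3)cs2)cc1F`: 29700 nM
compound 2, `COc1cc(/C=N/Nc2nc(-c3ccc(C(F)(F)F)cc3)cs2)c(Br)c(Br)c1OC`: > 100000 nM

In a functional assay on U-87MG ATCC cells for inhibition, with U-87 MG (Homo sapiens) as the target, read by MTT assay, with a stated time of 48 h (a higher number here means a weaker inhibitor, a lower number a stronger inhibitor), compound 1 gives 29700 nM. For the measured compounds named here, this is the only numerical value in the set, so compound 1 stands as the single measured number, with nothing to order it against. For compound 2 the entry > 100000 nM is a limit of the assay and not a number. That is the limit of > 100000 nM in this assay, at which 1 of the 2 values shown sits.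

Compound 3, `COc1cc(/C=N/Nc2nc(-c3cc(C(F)(F)F)cc(C(F)(F)F)c3)cs2)cc(Br)c1OC`, has not been measured. It differs from compound 1 in one place: 3-bromo-4,5-dimethoxyphenyl in place of 3,4-difluorophenyl on a carbon with a double bond to nitrogen, in words 3-bromo-4,5-dimethoxyphenyl in place of 3,4-difluorophenyl on a carbon with a double bond to nitrogen. Going by the values given here, no step between two measured compounds is available to calibrate this change; the pair compound 1 and compound 2 only shows one number and one limit, with differing structures elsewhere as well. The step from compound 1 to compound 3 is expected to go toward weaker inhibition, a 2.0-fold higher number from compound 1 to compound 3 (0.31 log units; beyond the scatter), beyond the usual scatter. It is also expected that compound 3 may return only a limit. For compound 3 the estimate in this assay is 60000 nM, within 20000 nM to 200000 nM.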

Compound 3, half-maximal inhibitory concentration: > 100000 nM
Compound 3: a limit, no number (the forecaster's own chance of this, stated with the estimate: 40%); middle value at least 1.6-fold (0.22 log units) from the limit.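

In this assay, 3-bromo-4,5-dimethoxyphenyl in place of 3,4-difluorophenyl on a carbon with a double bond to nitrogen gives an at least 3.3-fold higher number from compound 1 to compound 3 (0.52 log units; beyond the scatter), a reading of this single change with the rest of the structure held fixed, which the comparison with compound 2 could not give since that compound differs elsewhere as well. From the compounds shown here alone, compound 3 gives > 100000 nM, which is a limit of the assay and not a number, so the step has a lower bound only and its full size stays unknown. The 3,4-difluorophenyl group of compound 1 is now the only group at this place with a number, and the other readings give no order among themselves: the limit of > 100000 nM in this assay, at which 2 of the 3 values shown sit.

Still open, going by these compounds, is whether the bromine, the two methoxy groups or their combination accounts for the step, as compound 3 carries them together. Also open, on these data alone, is how a plain phenyl, or a phenyl bearing an amine or a carboxylic acid, would read at this place in this assay, and whether any group here gives a lower number than compound 1 at 29700 nM.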